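The compounds below may be only part of what the source reports. "The series", "measured", "known", "first", "only" and "open" are said of these compounds alone.

Measured in a functional assay on DU-145 cells (Homo sapiens) for inhibition, read by trypan blue exclusion, with a stated time of 96 h; on this read-out higher numbers stand for weaker inhibition of growth and lower numbers for stronger inhibition of growth:
- compound 1 `COc1ccc(/C=C(/SCc2ccc(Cl)cc2)C(=O)c2ccc(C(=O)O)cc2)cc1`: 10000 nM
- compound 2 `O=C(/C(=C\c1ccc[nH]1)SCc1ccc(Cl)cc1)c1ccc(Cl)cc1`: 10000 nM

Level with compound 1, compound 2 stands at 10000 nM, with no change at the digits shown and a gap within the scatter. These two values give no spread across the series and support no trend.

The next compound to be tested is compound 3 `COc1ccc(/C=C(/SCc2ccc(Cl)cc2)C(=O)c2ccc(Cl)cc2)cc1`. The change from compound 2 is 4-methoxyphenyl in place of 1H-pyrrol-2-yl on a double-bonded chain carbon bound to a double-bonded chain carbon.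

Among the measured compounds shown here, the series offers no measured step between compounds differing in one place, so the size of this step cannot be calibrated. The expectation rests on the structural change alone and is correspondingly loose. A moderate move toward stronger inhibition of growth is expected in this assay, although no move beyond the scatter remains possible. The estimated change is a 3.3-fold lower number from compound 2 to compound 3 (0.52 log units; beyond the scatter). For compound 3 the estimated value is 3000 nM, with an expected range from 400 nM to 10000 nM.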

Compound 3, concentration for 50% growth inhibition: 10000 nM
Compound 3: the middle estimate sits 3.3-fold (0.52 log units) below what was measured; the range from low to high includes it.
By their numbers in this assay, from the lowest: compounds 1, 2 and 3 (each within the scatter of the next).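

In this assay, 4-methoxyphenyl in place of 1H-pyrrol-2-yl on a double-bonded chain carbon bound to a double-bonded chain carbon gives no change at the digits printed from compound 2 to compound 3 (within the scatter), so this exchange of one aromatic ring for another does not separate the two compounds on this read-out. On an aromatic carbon, chloro in place of carboxy gives no change at the digits printed from compound 1 to compound 3 (within the scatter), so compound 3 provides a second single-place comparison, and it too shows no separation. No supporting measurement is available to account for either step.

The compounds shown leave open whether a dimethylamino group on the aromatic ring of compound 3 that carries chloro, or a longer chain on the double-bonded chain carbon, would move the result away from that of compound 3. On these data alone, with only these two steps, both within the scatter, it also remains open whether any single-place change on the shared core can shift growth inhibition in this assay.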